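Lengthening the saturated chain: compound 2 to compound 3

A few compounds are considered here, and "the series" means these few. Any claim that something is new, unique, unknown or untested is made for them only; others in the source may bear on it.

In a functional assay on CCRF-CEM cells (Homo sapiens) for cytotoxicity, read by MTT assay, with a stated time of 24 h (a lower number here means a stronger inhibitor, a higher number a weaker inhibitor), compound 1 (`CCCCCCCCCCC(=O)c1cc(O)c(O)c(O)c1`) gives 9800 nM and compound 2 (`CCCCCCCCCCCC(=O)c1cc(O)c(O)c(O)c1`) gives 21000 nM as the higher of the two numbers, which makes compound 2 the weaker inhibitor of the pair. Compound 3 (`CCCCCCCCCCCCC(=O)c1cc(O)c(O)c(O)c1`) differs from compound 2 by one further change (methyl in place of hydrogen on a saturated chain carbon, ten or more bonds along the chain from a carbonyl carbon), with methyl in place of hydrogen on a saturated chain carbon, ten or more bonds along the chain from a carbonyl carbon. Going by the values given here, the only measured step that bears on this is the same change (a 2.1-fold higher number from compound 1 to compound 2 (0.33 log units; beyond the scatter)), which is modest and beyond the scatter. A single step sets no firm trend, so a further modest rise is expected rather than assured. The expected step (a 1.7-fold higher number from compound 2 to compound 3 (0.22 log units; within the scatter)) is of similar size and in the same direction in this assay as an estimate. For compound 3 the estimated value is 35000 nM with an expected range from 15000 nM to 80000 nM on this read-out.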

Compound 3, half-maximal inhibitory concentration: 47400 nM
Compound 3: the middle estimate sits 1.4-fold (0.13 log units) below what was measured; the measured number falls inside the stated range.
By their numbers in this assay, from the lowest: compound 1; then compound 2; then compound 3.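

In this assay, a second methyl in place of hydrogen on a saturated chain carbon, ten or more bonds along the chain from a carbonyl carbon, again raises the number (a 2.3-fold higher number from compound 2 to compound 3 (0.35 log units; beyond the scatter)), so the first rise (a 2.1-fold higher number from compound 1 to compound 2 (0.33 log units; beyond the scatter)) no longer stands alone. Taken together, the two changes amount to ethyl in place of hydrogen at this place (a 4.8-fold higher number from compound 1 to compound 3 (0.68 log units; beyond the scatter)), and among compound 1, compound 2 and compound 3 each lengthening gives a weaker inhibitor, with none of the three going against this. No supporting data are available that would account for this rise.

From the compounds shown here alone, whether a longer chain continues the rise or levels it off remains open. Also open, going by these compounds, is how an amine or a carboxylic acid on the chain would shift the number.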